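From 4-methoxyphenyl to 2-methoxyphenyl in compound 3

The source may hold more compounds than are shown below. What is called first, only, known or untested is meant among the compounds shown, and "the series" means these compounds.

In a functional assay on FM3A cells (Mus musculus) for antiproliferative activity, with a stated time of 48 h (on this read-out lower numbers stand for stronger inhibition and higher numbers for weaker inhibition), compound 1 (`C=C(Br)C(=O)Nc1ccc(/C=C/C(=O)c2cccc(OC)c2)cc1`) gives 2700 nM, while compound 2 (`C=C(Br)C(=O)Nc1ccc(C(=O)/C=C/c2ccc(OC)cc2)cc1`) gives 1000 nM, the lower of the two numbers. Still unmeasured, compound 3 (`C=C(Br)C(=O)Nc1ccc(C(=O)/C=C/c2ccccc2OC)cc1`) carries 2-methoxyphenyl in place of 4-methoxyphenyl on a double-bonded chain carbon bound to a double-bonded chain carbon. For the measured compounds named here, no measured pair shows this change alone, so only a modest move toward weaker inhibition, hardly beyond the scatter, is expected in this assay. The expected change is a 1.5-fold higher number from compound 2 to compound 3 (0.18 log units; within the scatter). The estimated value for compound 3 is 1500 nM, with an expected range from 500 nM to 4500 nM.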

Compound 3, half-maximal inhibitory concentration: 370 nM
For compound 3 the middle estimate is 4.1-fold (0.61 log units) above the measured one; measured number below the stated range.
By their numbers in this assay, from the lowest: compound 3; then compound 2; then compound 1.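

Replacing 4-methoxyphenyl with 2-methoxyphenyl on a double-bonded chain carbon bound to a double-bonded chain carbon gives in this assay a 2.7-fold lower number from compound 2 to compound 3 (0.43 log units; beyond the scatter) toward stronger inhibition. The two groups have the same atoms and the same counts, so at this place the read-out depends on which of these two methoxyphenyl groups is present. Nothing shown here explains the difference. On these data alone, whether 2-hydroxyphenyl or 2-aminophenyl at the same place would keep the lower number stays open, as does the effect of a longer chain than methoxy on this ring.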